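Isopropylsulfanyl in place of hydrogen on compound 2

The compounds below may be only part of what the source reports. "The series", "measured", "known", "first", "only" and "open" are said of these compounds alone.

In a functional assay on HeLa cells (Homo sapiens) for cytotoxicity (a lower number here means a stronger inhibitor, a higher number a weaker inhibitor), compound 2 `CC1=CCC[C@H]2[C@](C)(CC3=CC(=O)C=CC3=O)[C@@H](C)CC[C@]12C` gives 26800 nM. Compound 1 `CC1=CCC[C@H]2[C@](C)(CC3=CC(=O)C(SC(C)(C)C)=CC3=O)[C@@H](C)CC[C@]12C` gives 37000 nM, and compound 3 `CC1CCC[C@H]2[C@](C)(CC3=CC(=O)C(Cl)=CC3=O)[C@@H](C)CC[C@]12C` gives 34100 nM. The value of compound 2 lies within the scatter of both others, so the three stand level on these numbers.

The unmeasured compound 4 `CC1=CCC[C@H]2[C@](C)(CC3=CC(=O)C(SC(C)C)=CC3=O)[C@@H](C)CC[C@]12C` carries isopropylsulfanyl in place of hydrogen on a double-bonded ring carbon of compound 2: isopropylsulfanyl in place of hydrogen on a double-bonded ring carbon.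

Among the measured compounds shown here, one measured step bears on this change. It runs the other way with a related group, hydrogen in place of (tert-butyl)sulfanyl on a double-bonded ring carbon, and amounts to a 1.4-fold lower number from compound 1 to compound 2 (0.14 log units; within the scatter). That step lies within the scatter. Compound 3 differs from compound 2 in more than one place, so it offers no single-change comparison. The evidence is therefore one small step, and no shift beyond the scatter is expected for isopropylsulfanyl. The middle of the expectation is placed between the values of the two compounds that differ only at this carbon. The estimated change is a 1.2-fold higher number from compound 2 to compound 4 (0.08 log units; within the scatter), which is expected to stay within the scatter. For compound 4 the estimated value is 32000 nM, with an expected range from 18000 nM to 56000 nM.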

Compound 4, half-maximal inhibitory concentration: 67000 nM
Compound 4: the middle estimate sits 2.1-fold (0.32 log units) below what was measured; measured number above the stated range.
By their numbers in this assay, from the lowest: compounds 2, 3, 1 and 4 (each within the scatter of the next, the first and the last beyond it).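

In this assay, among the compounds shown here, the double-bonded ring carbon now shows a step beyond the scatter: isopropylsulfanyl in place of hydrogen gives a 2.5-fold higher number from compound 2 to compound 4 (0.40 log units; beyond the scatter) on this carbon, whereas the only earlier comparison there, with (tert-butyl)sulfanyl, stayed within the scatter at a 1.4-fold lower number from compound 1 to compound 2 (0.14 log units; within the scatter) in the opposite direction. The two sulfur-bearing groups cannot be told apart on these numbers, since hydrogen in place of methyl on the saturated chain carbon bound to the sulfur gives a 1.8-fold higher number from compound 1 to compound 4 (0.26 log units; within the scatter) and so leaves compound 1 and compound 4 level. Nothing in the material shown accounts for the step from hydrogen to isopropylsulfanyl.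

The compounds shown leave open whether an amine or a carboxylic acid on this carbon, or a longer chain on the sulfur, would carry the number further in this assay or bring it back. Chlorine on this carbon appears only in compound 3, which differs from compound 2 in more than one place, so what that group does alone also remains open.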